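Moving the Nitro Group of Compound 3

A few compounds are considered here, and "the series" means these few. Any claim that something is new, unique, unknown or untested is made for them only; others in the source may bear on it.

Of the compounds shown here, three sharing one core have numbers so far. In a functional assay on SK-N-SH cells (Homo sapiens) for cytotoxicity, read by MTT assay, with a stated time of 24 h (on this read-out lower numbers stand for stronger inhibition and higher numbers for weaker inhibition), compound 1 (`C/C(=N\NC(=O)/C(C#N)=C/c1ccc(Br)cc1)c1c(O)c2ccc(O)cc2oc1=O`) gives 12100 nM and compound 2 (`C/C(=N\NC(=O)/C(C#N)=C/c1ccc(N(C)C)cc1)c1c(O)c2ccc(O)cc2oc1=O`) gives 6090 nM on the same read-out. Compound 3 (`C/C(=N\NC(=O)/C(C#N)=C/c1cccc([N+](=O)[O-])c1)c1c(O)c2ccc(O)cc2oc1=O`) gives 28300 nM and holds the highest of the three numbers, with both of its steps beyond the scatter.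

Compound 4 (`C/C(=N\NC(=O)/C(C#N)=C/c1ccc([N+](=O)[O-])cc1)c1c(O)c2ccc(O)cc2oc1=O`) has not yet been measured. It has 4-nitrophenyl in place of 3-nitrophenyl on a double-bonded chain carbon bound to a double-bonded chain carbon. Going by the values given here, no measured pair isolates this change, so the evidence is indirect. The steps of a 2.3-fold higher number from compound 1 to compound 3 (0.37 log units; beyond the scatter) and a 4.6-fold higher number from compound 2 to compound 3 (0.67 log units; beyond the scatter) are both modest, and each changes the substituent itself as well as where it sits. Compound 1 and compound 2 stay close (a 2.0-fold lower number from compound 1 to compound 2 (0.30 log units; within the scatter)) despite their different substituents, and compound 4 carries its nitro group where they carry theirs.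

A small move toward a lower number is therefore expected, not clearly beyond the scatter. The expected step is a 1.8-fold lower number from compound 3 to compound 4 (0.25 log units; within the scatter) on this estimate. For compound 4 the estimated value is 16000 nM with an expected range from 7000 nM to 36000 nM in this assay once it is measured.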

Compound 4, half-maximal inhibitory concentration: 10300 nM
Compound 4: middle estimate off by 1.6-fold (0.19 log units), on the high side; measured number inside the range.
By their numbers in this assay, from the lowest: compounds 2, 4 and 1 (each within the scatter of the next); then compound 3.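

In this assay, going by these compounds alone, the change from compound 3 to compound 4 is the first measured pair that isolates placement: with the same atoms, 4-nitrophenyl in place of 3-nitrophenyl on a double-bonded chain carbon bound to a double-bonded chain carbon gives a modest step beyond the scatter (a 2.7-fold lower number from compound 3 to compound 4 (0.44 log units; beyond the scatter)). The identity of the group, by contrast, does not separate the compounds carrying 4-bromophenyl, 4-(dimethylamino)phenyl and 4-nitrophenyl, as nitro in place of dimethylamino (a 1.7-fold higher number from compound 2 to compound 4 (0.23 log units; within the scatter)) and nitro in place of bromo (a 1.2-fold lower number from compound 1 to compound 4 (0.07 log units; within the scatter)) both stay within the scatter, so among these compounds only compound 3, the one compound with its group placed differently, stands apart. Nothing measured here accounts for the effect of moving the nitro group.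

As far as these compounds go, only the nitro group is seen in both placements, so it remains open whether moving bromo or dimethylamino in the same way would shift the number as well. From the compounds shown here alone, it is also open whether a carboxylic acid or a methoxy group on the same aromatic carbon would stay within the scatter of compound 4 or part from it.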